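This account rests on a few compounds, and the source may have more. Where it says the series, first, only, none or still open, it means among the compounds named here.

Measured so far:
- Compound 1, `C[C@@H]1O[C@@H](n2c3ccccc3c3c4c(c5c6ccccc6ccc5c32)C(=O)NC4=O)[C@H](O)[C@H](O)[C@H]1O`, gives 5000 nM in a functional assay on MDA-MB-468 cells (Homo sapiens) for cytotoxicity; on this read-out higher numbers stand for weaker inhibition and lower numbers for stronger inhibition.
- Compound 2, `O=C1NC(=O)c2c1c1c3ccccc3ccc1c1c2c2ccccc2n1[C@@H]1O[C@H](CO)[C@@H](O)[C@H]1O`, gives 4400 nM in this assay.

Compound 2 has the lower of the two numbers, but the gap to compound 1 is small: a 1.1-fold lower number from compound 1 to compound 2 (0.06 log units; within the scatter). The two compounds share the same core and differ only in the sugar-like ring on the aromatic nitrogen, so on this evidence swapping one sugar for another hardly moves the read-out.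

Compound 3, `O=C1NC(=O)c2c1c1c3ccccc3ccc1c1c2c2ccccc2n1[C@H]1C[C@H](O)[C@@H](CO)O1`, has not yet been measured. Its change from compound 2 is hydrogen in place of hydroxy on a saturated ring carbon. Within the data shown here, this is a smaller alteration than the one from compound 1 to compound 2, and it sits in the same part of the molecule, the sugar ring rather than the core. Among the measured compounds shown here, the only step that bears on it, from compound 1 to compound 2, lay within the scatter. The expectation is therefore no step beyond the scatter in either direction, a 1.1-fold lower number from compound 2 to compound 3 (0.04 log units; within the scatter). Compound 3 is estimated at 4000 nM, with a likely range from 1500 nM to 11000 nM.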

Compound 3, half-maximal inhibitory concentration: 9100 nM
For compound 3 the middle estimate is 2.3-fold (0.36 log units) below the measured one, and the stated range covers the measured number.
By their numbers in this assay, from the lowest: compounds 2, 1 and 3 (each within the scatter of the next, the first and the last beyond it).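

Taking the hydroxy off this saturated ring carbon, next to the ring atom that bears a large group, gives the first step in the series that passes the scatter: a 2.1-fold higher number from compound 2 to compound 3 (0.32 log units; beyond the scatter) in this assay. This shows that the position is not silent, even though the step is modest and rests on a single pair of compounds, whereas the earlier exchange of one whole sugar-like ring for another stayed within the scatter. The wider change from the six-membered ring of compound 1 to the 4-hydroxy-5-(hydroxymethyl)oxolan-2-yl group gives a 1.8-fold higher number from compound 1 to compound 3 (0.26 log units; within the scatter) and also stays within the scatter, and nothing measured here accounts for the shift seen on losing the hydroxy.

On these data alone, it remains open what an amine, a methoxy group or a fluorine on the same ring carbon would do, and whether any of them would give a number closer to that of compound 2 or to that of compound 3. Also open, as far as these compounds go, is whether taking away the neighbouring hydroxy, or the hydroxymethyl group, would move the number as far.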